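A few compounds are considered here, and "the series" means these few. Any claim that something is new, unique, unknown or untested is made for them only; others in the source may bear on it.

Compound 1 `CN(C)CCn1cnnc1-c1cc(Oc2ccc(NC(=O)N/N=C/c3cccc(O)c3)cc2F)ccn1` is the starting point. In a functional assay on MKN-45 cells (Homo sapiens) for cytotoxicity, read by MTT assay, with a stated time of 72 h (a higher number here means a weaker inhibitor, a lower number a stronger inhibitor), compound 1 gives 1370 nM, the highest of the three numbers measured, although a 1.7-fold lower number from compound 1 to compound 3 (0.22 log units; within the scatter) shows that the gap to compound 3 `CN(C)CCn1cnnc1-c1cc(Oc2ccc(NC(=O)N/N=C/c3ccc(O)cc3)cc2F)ccn1`, which gives 820 nM in this assay, is within the scatter. Among the compounds with values here, compound 2 `CN(C)CCn1cnnc1-c1cc(Oc2ccc(NC(=O)N/N=C/c3ccc(Cl)cc3)cc2F)ccn1` gives 570 nM in this assay, and a 2.4-fold lower number from compound 1 to compound 2 (0.38 log units; beyond the scatter) is the one step here that goes beyond the scatter. Between compound 2 and compound 3, a 1.4-fold higher number from compound 2 to compound 3 (0.16 log units; within the scatter) is within the scatter.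

Compound 4 `CN(C)CCn1cnnc1-c1cc(Oc2ccc(NC(=O)N/N=C/c3ccc(F)cc3F)cc2F)ccn1` is not yet measured. It differs from compound 1 in one place: 2,4-difluorophenyl in place of 3-hydroxyphenyl on a carbon with a double bond to nitrogen. The step that bears most on this change is a 2.4-fold lower number from compound 1 to compound 2 (0.38 log units; beyond the scatter), where a 3-hydroxyphenyl also gave way to a halogen-bearing phenyl with no hydrogen-bond donor or acceptor; the step of a 1.7-fold lower number from compound 1 to compound 3 (0.22 log units; within the scatter), where the hydroxy was kept, stayed within the scatter. A step of similar size to that of compound 2, toward a lower number, is therefore expected for compound 4, as a 2.3-fold lower number from compound 1 to compound 4 (0.36 log units; beyond the scatter). Compound 4 is estimated at 600 nM in this assay, with a range from 300 nM to 1400 nM.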

Compound 4, half-maximal inhibitory concentration: 810 nM
Estimate against measurement, compound 4: 1.4-fold (0.13 log units) below; the range from low to high includes it.
By their numbers in this assay, from the lowest: compounds 2, 4, 3 and 1 (each within the scatter of the next, the first and the last beyond it).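

In this assay, 2,4-difluorophenyl, which carries no hydrogen-bond donor, does not repeat the step seen with 4-chlorophenyl: a 1.7-fold lower number from compound 1 to compound 4 (0.23 log units; within the scatter) stays within the scatter, so replacing 3-hydroxyphenyl with a halogen-bearing phenyl does not by itself move the number beyond it. With a 1.0-fold lower number from compound 3 to compound 4 (0.01 log units; within the scatter) and a 1.4-fold higher number from compound 2 to compound 4 (0.15 log units; within the scatter), 2,4-difluorophenyl cannot be told apart from either 4-hydroxyphenyl or 4-chlorophenyl, so at this position hydroxy, chloro and fluoro substituents on the phenyl give numbers that mostly overlap. Nothing measured here explains why these phenyl groups read so alike. All the groups shown at this position are substituted phenyls, so it remains open how an amine or a carboxylic acid on that ring would read. The same is true of a saturated cyclohexyl ring in its place.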